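The source may report more compounds than this note shows. Statements on the series, on what has been measured and on what is new or still open speak of the compounds shown alone.

Of the compounds shown here, three on the shared core have been read so far in a physicochemical assay for solubility, at pH 7; on this read-out lower numbers stand for lower solubility and higher numbers for higher solubility. Compound 1 `CN1CCC(C(=O)N2Cc3c(NC(=O)c4ccsc4)n[nH]c3C2(C)C)CC1` gives > 225000 nM, which is a limit and not a number. Compound 2 `CN1CCC(C(=O)N2Cc3c(NC(=O)c4ccc(F)c(F)c4)n[nH]c3C2(C)C)CC1` gives > 225000 nM, again a limit. Compound 3 `CN1CCC(C(=O)N2Cc3c(NC(=O)c4ccncc4)n[nH]c3C2(C)C)CC1` gives > 225000 nM, also a limit, so compound 3 has no exact position on the scale. The whole set stands at the limit of > 225000 nM in this assay, at which 3 of the 3 values shown sit.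

Compound 4 `CCCNC(=O)Nc1n[nH]c2c1CN(C(=O)C1CCN(C)CC1)C2(C)C` is reached by propylamino in place of pyridin-4-yl on a carbonyl carbon.

Three measured swaps bear on this place: a step that the two limits leave unreadable from compound 1 to compound 3, a step that the two limits leave unreadable from compound 2 to compound 3 and a step that the two limits leave unreadable from compound 1 to compound 2. None has a readable size, so they give no direction in this assay. All three swaps exchange one ring for another, whereas propylamino has no ring, which leaves the new change untested. No shift beyond the scatter is therefore expected, and a further limit reading is the likeliest outcome. The expected change is a number no higher from compound 3 to compound 4 (the limit leaves the size open).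

Compound 4 is estimated at 225000 nM, within an expected range of 110000 nM to 450000 nM.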

Compound 4, solubility: > 225000 nM
Compound 4: only a limit was reported; the forecaster's own chance of this, stated with the estimate: 80%; the middle value lies on the limit itself.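

In this assay compound 4 gives > 225000 nM, which is a limit. Its steps from compound 1, compound 2 and compound 3 therefore cannot be read. The compounds shown leave open how the four compare and whether any change at this place gives an exact number: the limit of > 225000 nM in this assay, at which 4 of the 4 values shown sit.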